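Chain extension on the furan amide: compound 1 to compound 4

The source may report more compounds than this note shows. Statements on the series, on what has been measured and on what is new or still open speak of the compounds shown alone.

Compound 1 `CCCCCCCCCCCCNC(=O)[C@@H](NC(=O)c1ccco1)[C@@H](C)O` carries furan-2-yl on a carbonyl carbon and a straight alkyl chain on the second amide. In a functional assay on A-431 cells (Homo sapiens) for cytotoxicity, read by MTT assay, with a stated time of 48 h (a lower number here means a stronger inhibitor, a higher number a weaker inhibitor), compound 1 gives 92400 nM, the highest of the two numbers in the set. Compound 2 `CCCCCCCCCCCCNC(=O)[C@@H](NC(=O)c1cc2ccccc2o1)[C@@H](C)O` gives 20000 nM in this assay. Compound 3 `CCCCCCCCCCCCNC(=O)[C@@H](NC(=O)/C=C/c1ccccc1)[C@@H](C)O` gives only a limit, > 200000 nM, in this assay. One value in the set thus sits at the limit of > 200000 nM in this assay, at which 1 of the 3 values shown sits. Every measured step alters the group on the carbonyl carbon and leaves the chain untouched: a 4.6-fold lower number from compound 1 to compound 2 (0.66 log units; beyond the scatter); an at least 2.1-fold higher number from compound 1 to compound 3 (0.33 log units; beyond the scatter); an at least 10-fold higher number from compound 2 to compound 3 (1.00 log units; beyond the scatter).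

Compound 4 `CCCCCCCCCCCCCCCCCCNC(=O)[C@@H](NC(=O)c1ccco1)[C@@H](C)O` keeps the furan-2-yl acyl group of compound 1 and differs only in the chain: hexyl in place of hydrogen on a saturated chain carbon, ten or more bonds along the chain from an amide-type nitrogen. Among the compounds with values here, none of the measured steps bears on this change, so the set gives no reading of what chain length does in this assay. The expectation for compound 4 therefore rests on compound 1 alone, which gives 92400 nM, and is set with a wide range. Compound 4 is expected near 80000 nM, between 20000 nM and 250000 nM. The step from compound 1 to compound 4 is expected to be a 1.2-fold lower number from compound 1 to compound 4 (0.06 log units; within the scatter), within the scatter, with a real chance that only a limit is returned.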

Compound 4, half-maximal inhibitory concentration: 19900 nM
Estimate against measurement, compound 4: 4.0-fold (0.60 log units) above; the measured number lies below the stated range.
By their numbers in this assay, from the lowest: compounds 4 and 2 (each within the scatter of the next); then compound 1. At a limit, above all of these: compound 3.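

The chain on the second amide now proves to be a place that moves the number in this assay, since hexyl in place of hydrogen on a saturated chain carbon, ten or more bonds along the chain from an amide-type nitrogen, gives a 4.6-fold lower number from compound 1 to compound 4 (0.67 log units; beyond the scatter) with the furan-2-yl group unchanged. Every earlier step altered only the group on the carbonyl carbon, and the one that lowered the number, a 4.6-fold lower number from compound 1 to compound 2 (0.66 log units; beyond the scatter), is of much the same printed size as this chain step, so the two parts of the molecule have each shown a response on the furan amide. Nothing measured in the set bears on why the chain step occurs.

As far as these compounds go, two chain lengths on a single acyl group do not make a trend, and whether the same hexyl extension lowers the number on the 1-benzofuran-2-yl group of compound 2 or on the 2-phenylethenyl group of compound 3 stays open. Also open, from the compounds shown here alone, is whether a still longer chain continues in this direction, and whether an amine or a carboxylic acid in place of the hexyl keeps the step.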